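The compounds below may be only part of what the source reports. "The series", "measured", "known", "first", "only" and "open" are said of these compounds alone.

Measured so far:
Compound 1 `CCCCCCCCCCCCOc1ccc(C[S+]([O-])c2cccc(C(=O)O)c2)nc1/C=C/C(=O)O` gives 129 nM in an assay for binding affinity to leukotriene B4 receptor 1 (Homo sapiens); a higher number here means a weaker inhibitor, a lower number a stronger inhibitor.
Compound 2 `COc1ccc(CCCCCCCCOc2ccc(C[S+]([O-])c3cccc(CS(=O)(=O)C(F)(F)F)c3)nc2/C=C/C(=O)O)cc1` gives 225 nM in this assay.

Compound 2 and compound 1 lie within the usual scatter of each other in this assay, so neither can be called the stronger binder on these two numbers alone. Compound 3 `COc1ccc(CCCCCCCCOc2ccc(C[S+]([O-])c3cccc(N(C)C)c3)nc2/C=C/C(=O)O)cc1` has not been measured yet. It differs from compound 2 in a single place: dimethylamino in place of ((trifluoromethyl)sulfonyl)methyl on an aromatic carbon. Within the data shown here, no pair of measured compounds shows what this exchange does on its own, so nothing in the data fixes the size or direction of the step; the expectation rests on compound 2 and on the change itself. A move toward a weaker binder, somewhat beyond the scatter, is expected for compound 3, with the step of a 2.7-fold higher number from compound 2 to compound 3 (0.43 log units; beyond the scatter). Compound 3 is therefore estimated at 600 nM in this assay, with a range from 150 nM to 2500 nM.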

Compound 3, inhibition constant: 245 nM
Estimate against measurement, compound 3: 2.4-fold (0.39 log units) above; low and high end bracket the measured number.
By their numbers in this assay, from the lowest: compounds 1, 2 and 3 (each within the scatter of the next).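

In this assay, among these compounds, dimethylamino in place of ((trifluoromethyl)sulfonyl)methyl on this aromatic carbon gives a 1.1-fold higher number from compound 2 to compound 3 (0.04 log units; within the scatter), the first reading of a change made at this position alone. In this one pair, a group of 8 heavy atoms containing sulfur and fluorine and a group of 3 heavy atoms containing nitrogen give numbers that cannot be told apart, with the rest of the molecule held the same. No measurement available here offers a reason for this result.

On these data alone, it remains open whether a hydroxyl group, a nitrile or a plain hydrogen on this carbon would also give a number within the scatter of compound 2, or one beyond it. As far as these compounds go, it is also open whether this exchange would read the same with a different chain on the shared core.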